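A few compounds are considered here, and "the series" means these few. Any claim that something is new, unique, unknown or untested is made for them only; others in the source may bear on it.

Working notes on the series.

Compound 1 `Nc1nc2ccccc2c(=O)o1` carries a hydrogen on a nitrogen on an aromatic ring. In an assay on isolated protein for inhibition of complement C1r subcomponent (Homo sapiens) (on this read-out higher numbers stand for weaker inhibition and lower numbers for stronger inhibition), compound 1 gives only a limit, > 62500 nM. Compound 2 `O=c1oc(Nc2nc[nH]n2)nc2ccccc12` is the analogue with 1H-1,2,4-triazol-3-yl in place of hydrogen on a nitrogen on an aromatic ring. In this assay compound 2 likewise gives only a limit, > 62500 nM. The step that the two limits leave unreadable from compound 1 to compound 2 therefore cannot be sized, since both values sit at the limit of > 62500 nM in this assay, at which 2 of the 2 values shown sit. Compound 2 thus stands at the limit, with no number of its own.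

Compound 3 `O=c1oc(NC2CCSC2)nc2ccccc12` differs from compound 2 by thiolan-3-yl in place of 1H-1,2,4-triazol-3-yl on a nitrogen on an aromatic ring. No measured step bears on this change; the only step shown is unreadable, and both values sit at the same limit. Nothing beyond the scatter can be expected in either direction from what is shown. The step that the limit leaves unreadable from compound 2 to compound 3 is expected to be small. Compound 3 is estimated to come out near 70000 nM, in the range 8000 nM to 600000 nM, with a limit again likely.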

Compound 3, half-maximal inhibitory concentration: > 62500 nM
Compound 3: no number, only a limit (the forecaster's own chance of this, stated with the estimate: 75%); the middle value is on the limit's open side.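

In this assay compound 3 gives only a limit, so the steps to compound 3 from compound 1 and compound 2 cannot be read. The compounds shown leave open whether hydrogen, 1H-1,2,4-triazol-3-yl and thiolan-3-yl on this nitrogen differ at all in this assay once a number is available.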